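Hydroxy Addition in a Small Cytotoxicity Series

A few compounds are considered here, and "the series" means these few. Any claim that something is new, unique, unknown or untested is made for them only; others in the source may bear on it.

Measured so far, in a functional assay on MDA-MB-231 cells (Homo sapiens) for cytotoxicity, read by MTT assay; on this read-out lower numbers stand for stronger inhibition and higher numbers for weaker inhibition:
Compound 1 `COc1ccc(-n2cc(-c3ccc(O)c(OC)c3)nn2)cc1` gives > 10000 nM, which is a limit of the assay and not a number.
Compound 2 `COc1ccc(-c2cn(-c3ccc(OC)c(O)c3)nn2)cc1` gives > 100 nM, also a limit and not a number.
Compound 3 `COc1ccc(-c2cn(-c3ccc(OC)cc3)nn2)cc1` gives > 100 nM, again a limit and not a number.

Compound 3 and compound 2 differ in one place: hydroxy in place of hydrogen on an aromatic carbon. Because both sit at the limit of > 100 nM in this assay, at which 2 of the 3 values shown sit, the step that the two limits leave unreadable from compound 3 to compound 2 cannot be read from these results. Compound 1 rests instead at the limit of > 10000 nM in this assay, at which 1 of the 3 values shown sits, and the difference between the core of compound 1 and the core of compound 3 is not broken down here.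

Compound 4 `COc1ccc(-n2cc(-c3ccc(O)c(OC)c3)nn2)cc1O` has not yet been measured in this assay. It differs from compound 1 by hydroxy in place of hydrogen on an aromatic carbon, the same change as from compound 3 to compound 2, made at a place described in the same words. Since the earlier step is unreadable and compound 1 itself gave only (the limit of > 10000 nM in this assay, at which 1 of the 3 values shown sits), there is no measured basis for expecting a large gain; the expected step that the limit leaves unreadable from compound 1 to compound 4 is therefore small. For compound 4 the estimated value in this assay is 15000 nM, expected to fall between 3000 nM and 60000 nM, with a fair chance that only a limit is reported.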

Compound 4, half-maximal inhibitory concentration: > 10000 nM
Compound 4 was reported as a limit (the forecaster's own chance of this, stated with the estimate: 65%); the middle value is on the limit's open side.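

Compound 1 and compound 4 both rest at a limit of the assay and not at a number, so the step between them cannot be read: the limit of > 10000 nM in this assay, at which 2 of the 4 values shown sit. The compounds shown leave open whether hydroxy in place of hydrogen on an aromatic carbon changes the result in this assay at all, on the core of compound 1 or on that of compound 3.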